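The source may report more compounds than this note shows. Statements on the series, on what has been measured and on what is new or still open speak of the compounds shown alone.

Measured compounds and their values in a functional assay on DU-145 cells (Homo sapiens) for cytotoxicity, read by CCK-8 assay and cell counting, with a stated time of 2 days; on this read-out higher numbers stand for weaker inhibition and lower numbers for stronger inhibition:
- compound 1, `Oc1cccc(-c2cc(-c3cccc(Cl)c3)nc(-c3ccco3)c2)c1`: 2020 nM
- compound 2, `Oc1cccc(-c2cc(-c3ccc(Cl)cc3)nc(-c3ccco3)c2)c1`: 11400 nM
- compound 3, `Oc1ccc(-c2cc(-c3cccc(Cl)c3)nc(-c3ccco3)c2)cc1`: 5750 nM

Compound 1 gives the lowest number of the three in this assay; its steps to both other compounds lie beyond the scatter, so within this small set it is the strongest inhibitor. The two steps that are known, a 5.6-fold higher number from compound 1 to compound 2 (0.75 log units; beyond the scatter) and a 2.8-fold higher number from compound 1 to compound 3 (0.45 log units; beyond the scatter), both move the chlorine or the hydroxyl from one position to another on the outer phenyl rings and both raise the number modestly.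

Compound 4, `Oc1cccc(-c2cc(-c3ccccc3)nc(-c3cccc(Cl)c3)c2)c1`, is not yet measured. It differs from compound 1 at a different site: phenyl in place of furan-2-yl on an aromatic carbon. Within the data shown here, neither measured step touches this position or this kind of exchange, so no direct precedent exists for its size or direction. The measured steps only show that single changes on the periphery of the shared core shift the number by modest amounts, not by large ones.

For compound 4 the expected step in this assay is therefore a 1.2-fold higher number from compound 1 to compound 4 (0.09 log units; within the scatter), that is, no shift beyond the scatter, with a broad range to cover an unknown exchange. The estimate for compound 4 is 2500 nM, expected between 800 nM and 8000 nM.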

Compound 4, half-maximal inhibitory concentration: 2750 nM
The estimate for compound 4 lay 1.1-fold (0.04 log units) below the measured number; low and high end bracket the measured number.
By their numbers in this assay, from the lowest: compounds 1 and 4 (each within the scatter of the next); then compounds 3 and 2 (each within the scatter of the next).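

At the aromatic carbon next to the ring nitrogen, this assay gives a 1.4-fold higher number from compound 1 to compound 4 (0.13 log units; within the scatter) for phenyl in place of furan-2-yl, so this exchange of one aromatic ring for another shows no shift beyond the scatter, whereas both earlier steps, which moved the chlorine or the hydroxyl on the outer phenyl rings, lay beyond it. For this single pair, neither the five-membered ring nor the hydrogen-bond acceptor of furan-2-yl is needed to keep the number within the scatter, so the site accepts a six-membered aromatic ring of carbon only. Nothing available explains this outcome.

The compounds shown leave open whether this site would respond in the same way to a non-aromatic group such as cyclohexyl, to a basic ring such as piperidin-4-yl, or to a phenyl ring carrying a carboxylic acid. Among these compounds, it is also open whether the exchange of furan-2-yl for phenyl would give a similar step alongside 4-chlorophenyl or 4-hydroxyphenyl, the two placements that gave higher numbers in the earlier steps.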